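The source may hold more compounds than are shown below. What is called first, only, known or untested is meant among the compounds shown, and "the series" means these compounds.

Measured so far in a functional assay on L1210 cells (Mus musculus) for cytotoxicity, read by MTT assay, with a stated time of 24 h; on this read-out higher numbers stand for weaker inhibition and lower numbers for stronger inhibition:
- Compound 1 `COc1cc(C(=O)/C=C/c2ccc3ccccc3c2)ccc1O`: 54000 nM
- Compound 2 `COc1cc(C(=O)/C=C/c2ccc(Cl)c(Cl)c2)cc(OC)c1OC`: 44000 nM

For the measured compounds named here, with only two numbers available, there is little to compare. Compound 1 gives 54000 nM and compound 2 gives 44000 nM, and these values lie within the usual scatter of repeated measurements, so they cannot be ranked. Going by the values given here, compound 2 therefore stands level with the only other measured compound.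

The next compound is compound 3 `COc1cc(C(=O)/C=C/c2ccc(Br)cc2)cc(OC)c1OC`, which has 4-bromophenyl in place of 3,4-dichlorophenyl on a double-bonded chain carbon bound to a double-bonded chain carbon. The rest of the structure stays the same as in compound 2.

Among the compounds with values here, no measured pair differs in just one place, so the data offer no direct guide to this swap. Compound 1 and compound 2 differ in more than one place, yet compound 2 at 44000 nM stays within the scatter of compound 1, which is only weak support for expecting little change. In this assay, the expected change is no larger than the scatter, with an estimated 1.1-fold lower number from compound 2 to compound 3 (0.04 log units; within the scatter). For compound 3 the estimated value is 40000 nM, with an expected range of 16000 nM to 90000 nM.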

Compound 3, half-maximal inhibitory concentration: > 100000 nM
Compound 3 gave a limit, no number; the forecaster's own chance of this, stated with the estimate: 8%; at least 2.5-fold (0.39 log units) between middle value and limit.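

Compound 3 gave no exact number in this assay, only a limit: the limit of > 100000 nM in this assay, at which 1 of the 3 values shown sits.

Even so, this is the first pair in the series that differs in just one place, on a double-bonded chain carbon bound to a double-bonded chain carbon, and it gives an at least 2.2-fold higher number from compound 2 to compound 3 (0.35 log units; beyond the scatter). With the rest of the structure unchanged, 4-bromophenyl in place of 3,4-dichlorophenyl gives weaker inhibition, so the group at this place does affect the read-out, something the two earlier compounds, which differ in more than one place, could not show.

From the compounds shown here alone, the swap changes both the kind of halogen and how many halogens the ring carries, so this one pair cannot say which of the two matters, and the true size of the step stays open beyond the minimum printed with it. Also unanswered is how the same core would behave with a phenyl ring carrying a single chlorine, or with an amine or a carboxylic acid on that ring.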